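Nitro for methyl on the sulfonamide aryl: working notes

This account rests on a few compounds, and the source may have more. Where it says the series, first, only, none or still open, it means among the compounds named here.

Measured so far:
compound 1 `CCCC1CCC(c2ccc(-c3cn(Cc4cc(=O)oc5cc(O)ccc45)nn3)cc2)CC1` — 7910 nM
compound 2 `Cc1ccc(S(=O)(=O)NCc2cn(Cc3cc(=O)oc4cc(O)ccc34)nn2)cc1` — 30 nM

In an ADME assay on WI-38 cells (Homo sapiens) for inhibition, read by MTT assay, with a stated time of 72 h (on this read-out lower numbers stand for stronger inhibition and higher numbers for weaker inhibition), compound 2 gives 30 nM, the lowest of the two numbers; compound 1 gives 7910 nM, a gap beyond the scatter. Compound 3 `O=c1cc(Cn2cc(CNS(=O)(=O)c3ccc([N+](=O)[O-])cc3)nn2)c2ccc(O)cc2o1` differs from compound 2 by nitro in place of methyl on an aromatic carbon. Among the compounds with values here, no measured pair shows this change, so the size of the step is open; a small step, within the scatter or a modest rise, is expected rather than a large one. Compound 3 is expected to give 45 nM, between 12 nM and 170 nM. The expected step is a 1.5-fold higher number from compound 2 to compound 3 (0.18 log units; within the scatter).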

Compound 3, half-maximal inhibitory concentration: < 10 nM
Compound 3 was reported as a limit; the forecaster's own chance of this, stated with the estimate: 3%; at least 4.5-fold (0.65 log units) between middle value and limit.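

In this assay, within the data shown here, replacing 4-methylphenyl with 4-nitrophenyl gives an at least 3.0-fold lower number from compound 2 to compound 3 (0.47 log units; beyond the scatter), the first evidence that this position, para to a large group, responds to a single change and that nitro is accepted there without any loss. The result for compound 3 is a limit and not a number: the limit of < 10 nM in this assay, at which 1 of the 3 values shown sits.

From the compounds shown here alone, how far compound 3 lies past that limit therefore stays open, and the true size of the step with it. Also open, going by these compounds, is how an amine, a carboxylic acid or a longer chain would read at the same position.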